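Adding an amino group to a nucleoside core

The compounds below may be only part of what the source reports. "The series", "measured", "known", "first", "only" and "open" are said of these compounds alone.

Three nucleoside analogues have been tested in a functional assay on HepG2 cells (Homo sapiens) for antiproliferative activity, read by XTT assay, with a stated time of 72 h; a higher number here means a weaker inhibitor, a lower number a stronger inhibitor. Compound 3 `C#Cc1cn([C@@H]2O[C@H](CO)[C@@H](O)[C@H]2O)c2ncnc(OC)c12` gives 12700 nM. Compound 1 `C#Cc1cn([C@@H]2O[C@H](CO)[C@@H](O)[C@H]2O)c2nc(N)nc(OC)c12` reaches only the limit of this assay, > 20000 nM. The change from compound 3 to compound 1 is amino in place of hydrogen on an aromatic carbon, and it produced an at least 1.5-fold higher number from compound 3 to compound 1 (0.19 log units; that floor lies within the scatter); this agrees with the limit of > 20000 nM in this assay, at which 2 of the 3 values shown sit. Compound 2 `O=c1[nH]cnc2c1c(-c1cc3ccccc3o1)cn2[C@@H]1O[C@H](CO)[C@@H](O)[C@H]1O` also sits at the limit, > 20000 nM. The difference between the cores of compound 2 and compound 3 is not broken down here. Compound 4 `Nc1nc2c(c(-c3cc4ccccc4o3)cn2[C@@H]2O[C@H](CO)[C@@H](O)[C@H]2O)c(=O)[nH]1` is not yet measured; it differs from compound 2 by amino in place of hydrogen on an aromatic carbon, the same kind of change, the surroundings differing only in that the site lies meta to a group of 1 heavy atom rather than meta to a methoxy group. The step from compound 2 to compound 4 in this assay is expected to be a step that the limit leaves unreadable from compound 2 to compound 4, resting on compound 2 already giving > 20000 nM. Compound 4 is estimated at 30000 nM.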

Compound 4, half-maximal inhibitory concentration: > 20000 nM
Compound 4 ended at the assay's limit (the forecaster's own chance of this, stated with the estimate: 85%); the middle value lies beyond the limit too.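

Among the compounds shown here, compound 2 and compound 4 both stand at a limit in this assay, so no step between them can be read: the limit of > 20000 nM in this assay, at which 3 of the 4 values shown sit. As far as these compounds go, whether amino in place of hydrogen changes activity on the core of compound 2 stays open.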